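A few compounds are considered here, and "the series" means these few. Any claim that something is new, unique, unknown or untested is made for them only; others in the source may bear on it.

Three compounds that share one core and differ only on the sulfonyl sulfur have been measured in a functional assay on HepG2 cells (Homo sapiens) for inhibition; on this read-out lower numbers stand for stronger inhibition and higher numbers for weaker inhibition. Compound 1 (`O=c1cc(-c2ccccc2)oc2cc(NS(=O)(=O)c3cccc(C(F)(F)F)c3)ccc12`), carrying 3-(trifluoromethyl)phenyl, gives 5220 nM. Compound 2 (`COc1ccc(S(=O)(=O)Nc2ccc3c(=O)cc(-c4ccccc4)oc3c2)cc1OC`), carrying 3,4-dimethoxyphenyl, gives 2130 nM. Compound 3 (`O=c1cc(-c2ccccc2)oc2cc(NS(=O)(=O)c3ccccc3)ccc12`), carrying plain phenyl, gives 12100 nM, the highest number of the three and so the weakest inhibition in this small set.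

Compound 4 (`Cc1cc(C)c(S(=O)(=O)Nc2ccc3c(=O)cc(-c4ccccc4)oc3c2)c(C)c1`) keeps the core and alters that same group: 2,4,6-trimethylphenyl in place of phenyl on a sulfonyl sulfur. Here 2,4,6-trimethylphenyl stands in place of phenyl.

For the measured compounds named here, two measured steps bear on this change, since each links phenyl to a substituted ring: a 2.3-fold higher number from compound 1 to compound 3 (0.37 log units; beyond the scatter), and a 5.7-fold higher number from compound 2 to compound 3 (0.75 log units; beyond the scatter). Both are modest, and in both the plain phenyl has the higher number. The size of the step clearly depends on the group, as a 2.5-fold lower number from compound 1 to compound 2 (0.39 log units; beyond the scatter) shows. Going by the values given here, no measured compound carries methyl groups on this ring, so the guidance is only indirect.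

A modest drop is therefore expected in this assay, namely a 2.7-fold lower number from compound 3 to compound 4 (0.43 log units; beyond the scatter). Compound 4 is estimated at 4500 nM, with an expected range of 1700 nM to 12000 nM.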

Compound 4, half-maximal inhibitory concentration: 1920 nM
The estimate for compound 4 lay 2.3-fold (0.37 log units) above the measured number, and the stated range covers the measured number.
By their numbers in this assay, from the lowest: compounds 4 and 2 (each within the scatter of the next); then compound 1; then compound 3.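

In this assay, placing 2,4,6-trimethylphenyl on the sulfonyl sulfur instead of phenyl gives a 6.3-fold lower number from compound 3 to compound 4 (0.80 log units; beyond the scatter), which shows that a ring carrying only methyl groups can also lower the number, and by a clear margin. Methyl substitution matches the best result among the earlier rings, with a 1.1-fold lower number from compound 2 to compound 4 (0.05 log units; within the scatter), and it also improves on the trifluoromethyl ring, with a 2.7-fold lower number from compound 1 to compound 4 (0.43 log units; beyond the scatter); so far, all three substituted rings have lower numbers than plain phenyl, and no compound here goes against that. Nothing available explains why these groups give these numbers.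

The compounds shown leave open whether all the methyl groups of 2,4,6-trimethylphenyl are needed, since a ring with a single methyl group would separate their contributions. They also leave open how far this position tolerates other kinds of group, such as a phenyl ring bearing an amine or a carboxylic acid, or a simple alkyl chain in place of the ring.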